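A few compounds are considered here, and "the series" means these few. Any claim that something is new, unique, unknown or untested is made for them only; others in the source may bear on it.

Measured compounds:
Compound 1 `COc1cccc(C(=O)Nc2ccc(Cl)cc2CN2C(=O)c3ccccc3C2=O)c1` gives 1500 nM
Compound 2 `COc1ccc(NC(=O)c2ccccn2)c(CN2C(=O)c3ccccc3C2=O)c1` gives 1400 nM

The account follows the step from compound 2 to compound 3 in an assay on CHO cells for positive allosteric modulation of metabotropic glutamate receptor 5 (Homo sapiens), read by FLIPR; a higher number here means that more compound is needed for the effect, a lower number that less compound is needed. Within the data shown here, only two numbers are known there. In this assay compound 1 gives 1500 nM and compound 2 gives 1400 nM; the two values lie within the scatter of one another, so neither compound can be placed apart from the other, and compound 2 stands at the same level as compound 1 on the numbers available.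

Compound 3 `O=C(Nc1ccc(F)cc1CN1C(=O)c2ccccc2C1=O)c1ccccn1` keeps the core of compound 2 and changes a single place: fluoro in place of methoxy on an aromatic carbon. Among the measured compounds shown here, no step between two measured compounds isolates this exchange, so there is no measured step to lean on. Compound 3 is expected to stay close to compound 2, with a step of a 1.1-fold higher number from compound 2 to compound 3 (0.06 log units; within the scatter) in this assay, a change that may well fall within the scatter and is not expected to be large in either direction. Compound 3 is therefore estimated at 1600 nM in this assay, with a range from 500 nM to 5000 nM.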

Compound 3, half-maximal effective concentration: 1500 nM
Beside the measured number, compound 3's estimate is 1.1-fold (0.03 log units) above it, within the range that was stated.
By their numbers in this assay, from the lowest: compounds 2, 1 and 3 (each within the scatter of the next).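

Fluoro in place of methoxy, on the aromatic carbon para to the ((pyridin-2-yl)carbonyl)amino group, gives a 1.1-fold higher number from compound 2 to compound 3 (0.03 log units; within the scatter) in this assay, a reading of this one exchange that compound 1 and compound 2 could not give, since those two differ in more than one place. The position therefore accepts a swap from two heavy atoms to one, and from a group counted with a hydrogen-bond acceptor to one counted without, while the numbers of the two compounds cannot be told apart. Nothing measured here bears on why the two groups read alike.

What the compounds shown leave open is how far this holds at the same aromatic carbon for a group of another kind, such as an amine, a carboxylic acid or a longer chain, since methoxy and fluoro alone give no trend. They also leave open whether fluoro and methoxy would still read alike with another group in place of the ((pyridin-2-yl)carbonyl)amino group.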